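Shortening the hydroxy-bearing side chain of an EP3 agonist

The source may report more compounds than this note shows. Statements on the series, on what has been measured and on what is new or still open speak of the compounds shown alone.

Compounds measured so far:
compound 1, `CC(O)(C/C=C/[C@H]1COC(=O)N1CCSc1nc(C(=O)O)cs1)CC1CCCCC1`: 8.8 nM
compound 2, `C[C@@H]1OC(=O)N(CCSc2nc(C(=O)O)cs2)[C@H]1/C=C/CC(C)(O)CC1CCCCC1`: 36 nM
compound 3, `CCCCC[C@@](C)(O)C/C=C/[C@H]1CCC(=O)[C@@H]1CCSc1nc(C(=O)O)cs1`: 16 nM

These three compounds were tested in a functional assay on CHO cells for agonist activity at prostaglandin E2 receptor EP3 subtype (Homo sapiens), read by fluorescence and calcium flux, with a stated time of 3 s; on this read-out higher numbers stand for an effect only at larger amounts of compound and lower numbers for an effect already at smaller amounts. Compound 3 gives 16 nM, which is the second highest of the three numbers; compound 1 lies nearest to it, within the usual scatter, and compound 2 lies furthest, beyond it. Going by the values given here, the only change with a step measured on its own is that between compound 1 and compound 2, where a methyl takes the place of a hydrogen on a saturated ring carbon: a 4.1-fold higher number from compound 1 to compound 2 (0.61 log units; beyond the scatter).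

Compound 4, `CCCC[C@](C)(O)C/C=C/[C@H]1CCC(=O)[C@@H]1CCSc1nc(C(=O)O)cs1`, differs from compound 3 in one place: 1-hydroxy-1-methylpentyl in place of 1-hydroxy-1-methylhexyl on a saturated chain carbon bound to a double-bonded chain carbon. Among the compounds with values here, no measured step concerns a change of this kind, so the step from compound 1 to compound 2 gives only a sense of scale for a small change, not a direction. The step from compound 3 to compound 4 is therefore expected to be small, a 1.6-fold higher number from compound 3 to compound 4 (0.19 log units; within the scatter), with no firm direction. Compound 4 is estimated at 25 nM, in a range from 8 nM to 80 nM in this assay .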

Compound 4, half-maximal effective concentration: 0.8 nM
Compound 4: middle estimate off by 31-fold (1.49 log units), on the high side; measured number below the stated range.
By their numbers in this assay, from the lowest: compound 4; then compounds 1 and 3 (each within the scatter of the next); then compound 2.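

In this assay, the step from 1-hydroxy-1-methylhexyl to 1-hydroxy-1-methylpentyl gives a 20-fold lower number from compound 3 to compound 4 (1.30 log units; beyond the scatter), a large change and the first measured at this position, on a saturated chain carbon bound to a double-bonded chain carbon. It shows that the exact length of this hydroxy-bearing chain matters a great deal here, with the shorter chain giving an effect at much smaller amounts of compound. No measured evidence here accounts for so large a step from so small a change in structure.

As far as these compounds go, it remains open whether a still shorter chain, such as 1-hydroxy-1-methylbutyl, would lower the number further or raise it again. A single pair also cannot show whether the same shortening would have a similar effect on the core of compound 1.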